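Methyl to hydrogen at two places on a shared amide core

The source may report more compounds than this note shows. Statements on the series, on what has been measured and on what is new or still open speak of the compounds shown alone.

Measured so far:
Compound 1, `CC[C@@H](C)[C@H](N)CN(C(=O)[C@@H]1C[C@H]1c1ccccc1)c1ccc(-c2ccccc2)cc1` — 1.4 nM
Compound 2, `CC(C)[C@H](N)CN(C(=O)[C@@H]1C[C@H]1c1ccccc1)c1ccc(-c2ccccc2)cc1` — 1.1 nM
Compound 3, `CCOc1ccc(-c2ccc(N(C[C@@H](N)[C@@H](C)CC)C(=O)[C@@H]3C[C@H]3c3ccccc3)cc2)cc1` — 90 nM

Of the compounds shown here, three share one amide core and have been tested in a functional assay for agonist activity at G protein-coupled receptor 88 (Homo sapiens), read by HTRF and cAMP accumulation; a higher number here means that more compound is needed for the effect, a lower number that less compound is needed. Compound 1 gives 1.4 nM and compound 2 gives 1.1 nM; the change between them is hydrogen in place of methyl on a saturated chain carbon, three bonds along the chain from an amine nitrogen, and the step of a 1.3-fold lower number from compound 1 to compound 2 (0.10 log units; within the scatter) is within the scatter. Compound 3 gives 90 nM, the highest of the three numbers; how its core differs from that of compound 1 is not broken down here, so only the two values themselves can be compared.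

Compound 4, `CC[C@H](C)[C@H](N)CN(C(=O)[C@@H]1C[C@H]1c1ccccc1)c1ccc(-c2ccc(OC)cc2)cc1`, has not yet been measured. It differs from compound 3 by hydrogen in place of methyl on a saturated chain carbon bound to an oxygen on an aromatic ring. This is the same kind of change as that from compound 1 to compound 2, but not the same change: there the place was a saturated chain carbon three bonds along the chain from an amine nitrogen, here it is a saturated chain carbon bound to an oxygen on an aromatic ring. The earlier step therefore gives only weak guidance. What can be said is that compound 1, which carries no ethoxy group, gives 1.4 nM while compound 3 gives 90 nM, so shortening that group might be expected to move compound 4 part of the way back. The expected step in this assay is a 2.3-fold lower number from compound 3 to compound 4 (0.35 log units; beyond the scatter), and compound 4 is estimated at 40 nM, between 12 nM and 130 nM.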

Compound 4, half-maximal effective concentration: 120 nM
Compound 4: the middle estimate sits 3.0-fold (0.48 log units) below what was measured, and the stated range covers the measured number.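

In this assay, among these compounds, going from 4-ethoxyphenyl to 4-methoxyphenyl gives a 1.3-fold higher number from compound 3 to compound 4 (0.12 log units; within the scatter), so removing this one carbon from the ethoxy group produces no step that can be told from the scatter. Hydrogen in place of methyl therefore leaves the number unchanged within the scatter at both places examined, and the two steps do not differ from each other: the same change on two cores in this assay, a 1.3-fold lower number (0.10 log units; within the scatter) from compound 1 to compound 2 and a 1.3-fold higher number (0.12 log units; within the scatter) from compound 3 to compound 4, 1.7-fold (0.23 log units) apart, within the scatter of two such steps

Among the compounds shown here, this shows that, in these two cases, the change carried from one core to another without a readable step, but it does not show that the change is without effect throughout the series, since each core supplies only one pair and the change sits at a different place on each.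

The compounds shown leave open whether a longer chain such as propoxy, or a hydroxyl or an amine, in the place of the ethoxy or methoxy group would give a similarly small step. They also leave open whether hydrogen in place of methyl on the saturated chain carbon three bonds along the chain from an amine nitrogen would behave the same way on a core carrying 4-ethoxyphenyl or 4-methoxyphenyl.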